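Removing the Methoxy from Compound 3's Acid Chain

The source may report more compounds than this note shows. Statements on the series, on what has been measured and on what is new or still open speak of the compounds shown alone.

Measured in a functional assay on CHO cells for antagonist activity at sphingosine 1-phosphate receptor 2 (Homo sapiens), read by calcium flux; a higher number here means a weaker inhibitor, a lower number a stronger inhibitor:
Compound 1, `CCOc1cc2nn(Cc3nn(CC(=O)O)c(=O)c4ccccc34)cc2cc1Cl`, gives > 6640 nM, which is a limit of the assay and not a number.
Compound 2, `O=C(O)Cn1nc(Cc2nc3cc(F)c(OCC4CC4)cc3[nH]2)c2ccccc2c1=O`, gives 18 nM.
Compound 3, `COC(C(=O)O)c1nn(Cc2cn3cc(OCC4CC4)c(Cl)cc3n2)c2ccccc2c1=O`, gives 23 nM.

Among the two numbers in this assay, compound 3 holds the higher one, yet its gap to compound 2 lies within the usual scatter, so no order between them can be claimed. The value of compound 1 stands as a limit of this assay, as stated by the limit of > 6640 nM in this assay, at which 1 of the 3 values shown sits.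

Compound 4, `O=C(O)Cc1nn(Cc2cn3cc(OCC4CC4)c(Cl)cc3n2)c2ccccc2c1=O`, has not yet been measured. It differs from compound 3 in one place: hydrogen in place of methoxy on a saturated chain carbon bound to an aromatic carbon and a carbonyl carbon. Stated as the group that changes, the carboxy(methoxy)methyl of compound 3 becomes a carboxymethyl in compound 4.

Going by the values given here, no step between measured compounds with this difference is available, so the size of the step cannot be read from the data. Compound 2, which carries a carboxymethyl chain, and compound 3, which carries the methoxy variant, sit within the scatter of each other on different cores, which gives no sign that the methoxy matters much. The step from compound 3 to compound 4 in this assay is therefore expected to be small, a 1.2-fold lower number from compound 3 to compound 4 (0.06 log units; within the scatter), in no clear direction. Compound 4 is estimated to give 20 nM, with the likely range running from 8 nM to 60 nM.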

Compound 4, half-maximal inhibitory concentration: 20 nM
Estimate against measurement, compound 4: no gap at the digits printed; the range from low to high includes it.
By their numbers in this assay, from the lowest: compounds 2, 4 and 3 (each within the scatter of the next). At a limit, above all of these: compound 1.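

In this assay, going by these compounds alone, this is the first reading of the methoxy on its own, on an otherwise unaltered compound: a 1.2-fold lower number from compound 3 to compound 4 (0.06 log units; within the scatter). Within the data shown here, compound 3 and compound 4 therefore cannot be told apart, which shows that on this core a methoxy on a saturated chain carbon bound to an aromatic carbon and a carbonyl carbon can give way to hydrogen with no measurable consequence for the read-out, something the earlier compounds could not show because they differ from one another in more than one place. The data shown offer no measured property that would explain this result, and none bears on why the two compounds read alike.

What the compounds leave open is how much this carbon tolerates beyond these two cases, since a hydroxyl, an amine or a larger ethoxy there would each test it further. Also open, on these data alone, is whether the chain itself can vary, for instance a longer carboxyethyl chain, or a primary amide or tetrazole in place of the carboxylic acid.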